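Cyclohexyl for methyl next to the ring oxygen

A few compounds are considered here, and "the series" means these few. Any claim that something is new, unique, unknown or untested is made for them only; others in the source may bear on it.

In a functional assay on SK-BR-3 cells (Homo sapiens) for cytotoxicity, read by MTT assay, with a stated time of 72 h (a lower number here means that less compound is needed, a higher number that more compound is needed for the effect), compound 1 `COc1cccc(Nc2cc(-c3ccccc3)oc(=O)c2)c1` gives 0.74 uM. Compound 2 `O=c1cc(NC2CC2)cc(-c2ccccc2)o1` reaches only a limit of this assay, > 30 uM, not a number. Compound 3 `COc1ccc(Nc2cc(C)oc(=O)c2)cc1` likewise stops at a limit in this assay, > 30 uM, so no number stands for it. Where compound 3 stands is therefore told only by that limit (the limit of > 30 uM in this assay, at which 2 of the 3 values shown sit), which it shares with compound 2, while compound 1 alone carries a measured number. For the measured compounds named here, no two of the measured compounds differ in a single place, so no measured step is available.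

Compound 4 `COc1ccc(Nc2cc(C3CCCCC3)oc(=O)c2)cc1` differs from compound 3 by cyclohexyl in place of methyl on an aromatic carbon, on an aromatic carbon of a six-membered aromatic ring with 1 oxygen, next to the ring oxygen. Nothing measured here shows how a larger group at that carbon acts on its own, since compound 1 carries phenyl there but also a differently placed methoxy on the anilino group. Compound 3 sets only a limit, so an expected step can run only downward from it, with a real chance that compound 4 again reports a limit. As an estimate, compound 4 is expected at 6 uM in this assay, within 1.5 uM to 30 uM, which would mean a step of an at least 5.0-fold lower number from compound 3 to compound 4 (0.69 log units; beyond the scatter).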

Compound 4, concentration for half-maximal effect: 5.29 uM
Compound 4: the middle estimate sits 1.1-fold (0.05 log units) above what was measured; the range from low to high includes it.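

With the rest of the structure held fixed, cyclohexyl in place of methyl on the aromatic carbon next to the ring oxygen gives an at least 5.6-fold lower number from compound 3 to compound 4 (0.75 log units; beyond the scatter). For the compounds shown here, this is the only single-place step so far, and it shows that this carbon is a point at which a change of group alters the read-out of this assay, with a six-membered non-aromatic carbon ring accepted there in place of methyl. The size of the step is a floor and not a measured gap, because compound 3 carries only a limit of the assay: the limit of > 30 uM in this assay, at which 2 of the 4 values shown sit.

Open, on these data alone, is whether a smaller carbon group than cyclohexyl at this carbon, such as isopropyl or a short butyl chain, would already give a measurable value, and whether an amine or a carboxylic acid carried on that ring would keep it. Also open, as far as these compounds go, is how phenyl and cyclohexyl compare at this carbon with the rest of the structure held the same, since compound 1 and compound 4 differ in more than one place and cannot settle that.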